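The compounds below may be only part of what the source reports. "The series", "measured", "known", "first", "only" and "open" are said of these compounds alone.

Measured so far:
Compound 1 `CC(C)(C)N(NC(=O)c1ccccc1)C(=O)c1ccccc1Cl` gives 75.9 nM in an assay on cells for agonist activity at ecdysone receptor (Bombyx mori), read by a luciferase reporter, with a stated time of 24 h; a higher number here means that more compound is needed for the effect, a lower number that less compound is needed.
Compound 2 `Cc1ccccc1C(=O)NN(C(=O)c1ccccc1Cl)C(C)(C)C` gives 72.4 nM in this assay.
Compound 3 `CC(C)(C)N(NC(=O)c1cccc(C#N)c1)C(=O)c1ccccc1Cl` gives 955 nM in this assay.

Compound 1 stands second highest of the three numbers. Its nearest neighbour is compound 2, with a 1.0-fold lower number from compound 1 to compound 2 (0.02 log units; within the scatter); its furthest is compound 3, with a 13-fold higher number from compound 1 to compound 3 (1.10 log units; beyond the scatter). Compound 2 and compound 3 differ by a 13-fold higher number from compound 2 to compound 3 (1.12 log units; beyond the scatter).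

Compound 4 `COc1ccc(C(=O)NN(C(=O)c2ccccc2Cl)C(C)(C)C)cc1` has not yet been measured in this assay. It differs from compound 1 as follows: methoxy in place of hydrogen on an aromatic carbon. The group sits on an aromatic carbon of a six-membered aromatic ring of carbon only, para to a large group.

Going by the values given here, two measured steps touch the same ring. The step from compound 1 to compound 2 shows that a methyl on this ring leaves the number unchanged within the scatter. The step from compound 1 to compound 3 shows that a cyano on this ring raises the number a great deal. Among the compounds with values here, no measured step brings a methoxy onto the ring, and none alters the ring at the position taken here, so the direction for compound 4 cannot be read directly from the data. The expectation for compound 4 is therefore a step of a 1.4-fold lower number from compound 1 to compound 4 (0.14 log units; within the scatter), lying within or close to the scatter, in either direction.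

Compound 4 is thus estimated at 55 nM, with a range from 15 nM to 200 nM.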

Compound 4, half-maximal effective concentration: 51.3 nM
Estimate against measurement, compound 4: 1.1-fold (0.03 log units) above, and the stated range covers the measured number.
By their numbers in this assay, from the lowest: compounds 4, 2 and 1 (each within the scatter of the next); then compound 3.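

In this assay, going by these compounds alone, the step of methoxy in place of hydrogen on an aromatic carbon, para to a large group, is (a 1.5-fold lower number from compound 1 to compound 4 (0.17 log units; within the scatter)), which shows for the first time that this position takes a substituent without moving the number beyond the scatter. The step from the 2-methylphenyl compound also stays within the scatter (a 1.4-fold lower number from compound 2 to compound 4 (0.15 log units; within the scatter)), whereas the step from the 3-cyanophenyl compound is large (a 19-fold lower number from compound 3 to compound 4 (1.27 log units; beyond the scatter)), so among the four compounds a substituent on this ring leaves the number within the scatter, with compound 3 as the one exception. Nothing in the material shown accounts for this difference between the methoxy and the cyano compounds.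

The compounds shown leave open whether the large step of compound 3 belongs to the cyano group itself or to its place on the ring, as none of them carries a cyano where compound 4 carries its methoxy. From the compounds shown here alone, they also leave open how a primary amine, a carboxylic acid or a longer chain such as butoxy would read at this place, so the room for larger or charged groups here remains unknown.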